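Chloro addition on the hydroxyphenyl amide of the coumarin series

A few compounds are considered here, and "the series" means these few. Any claim that something is new, unique, unknown or untested is made for them only; others in the source may bear on it.

Measured so far in a functional assay on SK-BR-3 cells (Homo sapiens) for antiproliferative activity; a higher number here means a weaker inhibitor, a lower number a stronger inhibitor:
Compound 1 `CC(=O)Oc1ccc(C(=O)Nc2cc3ccc(OC4CCN(C)CC4)c(C)c3oc2=O)cc1` gives 1670 nM.
Compound 2 `CC(=O)Oc1ccc(C(=O)Nc2cc3ccc(OC4CCN(C)CC4)c(C)c3oc2=O)cc1Cl` gives 3500 nM.
Compound 3 `Cc1c(OC2CCN(C)CC2)ccc2cc(NC(=O)c3ccc(O)cc3)c(=O)oc12` gives 840 nM.

Compound 4 `Cc1c(OC2CCN(C)CC2)ccc2cc(NC(=O)c3ccc(O)c(Cl)c3)c(=O)oc12` is not yet measured. The change from compound 3 to compound 4 is chloro in place of hydrogen on an aromatic carbon. The same change has been made once before, from compound 1 to compound 2: chloro in place of hydrogen on an aromatic carbon; there it gave a 2.1-fold higher number from compound 1 to compound 2 (0.32 log units; beyond the scatter). The two cores differ as well: hydrogen in place of acetyl on an oxygen on an aromatic ring, which moved the number by a 2.0-fold lower number from compound 1 to compound 3 (0.30 log units; within the scatter). The surroundings of the place are not identical: in compound 2 the chloro sits ortho to an acetoxy group (4 heavy atoms), in compound 4 ortho to a hydroxy group (1 heavy atom), so this is the same kind of change rather than the same one. Within the data shown here, for compound 4 a step like that from compound 1 to compound 2 is expected, because a 2.1-fold higher number from compound 1 to compound 2 (0.32 log units; beyond the scatter) is the only precedent; the expected step is a 2.0-fold higher number from compound 3 to compound 4 (0.31 log units; beyond the scatter). Compound 4 is therefore estimated at 1700 nM in this assay, within 800 nM to 3600 nM.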

Compound 4, half-maximal inhibitory concentration: 2300 nM
Beside the measured number, compound 4's estimate is 1.4-fold (0.13 log units) below it; low and high end bracket the measured number.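

In this assay chloro in place of hydrogen gives a 2.7-fold higher number from compound 3 to compound 4 (0.44 log units; beyond the scatter), and this step carries over from the acetoxy pair to the hydroxy pair: the same change on two cores in this assay, a 2.1-fold higher number (0.32 log units; beyond the scatter) from compound 1 to compound 2 and a 2.7-fold higher number (0.44 log units; beyond the scatter) from compound 3 to compound 4, 1.3-fold (0.12 log units) apart, within the scatter of two such steps. Hydrogen in place of acetyl gives a 1.5-fold lower number from compound 2 to compound 4 (0.18 log units; within the scatter), and this step likewise reads alike with and without the chloro: the same change on two cores in this assay, a 2.0-fold lower number (0.30 log units; within the scatter) from compound 1 to compound 3 and a 1.5-fold lower number (0.18 log units; within the scatter) from compound 2 to compound 4, 1.3-fold (0.12 log units) apart, within the scatter of two such steps. With both changes together the series gives a 1.4-fold higher number from compound 1 to compound 4 (0.14 log units; within the scatter), but this agreement rests on these four compounds and two cores alone, and it does not show how the chloro acts or whether the step holds on any other core.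

From the compounds shown here alone, whether fluoro, bromo or methyl in place of the chloro gives a step of similar size remains open. So does whether a methoxy group in place of the hydroxy group leaves the chloro step unchanged.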